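A few compounds are considered here, and "the series" means these few. Any claim that something is new, unique, unknown or untested is made for them only; others in the source may bear on it.

Compound 1 `CCOC(=O)c1c(C)[nH]c(=O)c(C#N)c1-c1ccccc1` is the parent of the series. In a functional assay on SK-OV-3 cells (Homo sapiens) for inhibition, read by MTT assay, with a stated time of 24 h (on this read-out higher numbers stand for weaker inhibition and lower numbers for stronger inhibition), compound 1 gives > 100000 nM, which is a limit of the assay and not a number. Compound 2 `CCOC(=O)c1c(C)[nH]c(=O)c(C#N)c1-c1ccc(C)cc1` differs from it by methyl in place of hydrogen on an aromatic carbon. In this assay compound 2 gives > 100000 nM, again a limit and not a number. The step that the two limits leave unreadable from compound 1 to compound 2 is therefore unreadable. Where compound 2 stands is set only by the limit of > 100000 nM in this assay, at which 2 of the 2 values shown sit; no measured value of the series lies inside the measurable range. Compound 3 `CCOC(=O)c1c(C)[nH]c(=O)c(C#N)c1-c1ccc(OC)cc1` is the next member, differing from compound 2 by methoxy in place of methyl on an aromatic carbon. Going by the values given here, the only measured step that bears on a change at this position, a step that the two limits leave unreadable from compound 1 to compound 2, has no readable size, so the numbers give neither a size nor a direction to expect. The step from compound 2 to compound 3 in this assay is estimated as a number no higher from compound 2 to compound 3 (the limit leaves the size open), within the scatter. Compound 3 is expected to give 100000 nM, with a range from 30000 nM to 300000 nM, most likely reported once more only as a limit.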

Compound 3, half-maximal inhibitory concentration: > 100000 nM
Compound 3: a limit, no number (the forecaster's own chance of this, stated with the estimate: 80%); the middle value lies on the limit itself.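

No step can be read among compound 1, compound 2 and compound 3, since all three results in this assay are limits of the assay and not numbers: the limit of > 100000 nM in this assay, at which 3 of the 3 values shown sit. The compounds shown leave open whether hydrogen, methyl or methoxy on this aromatic carbon makes any difference to inhibition within the measurable range.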